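From methyl to phenyl on compound 3

This account rests on a few compounds, and the source may have more. Where it says the series, first, only, none or still open, it means among the compounds named here.

In an ADME assay on HEK-293T cells (Homo sapiens) for inhibition, read by CCK-8 assay, with a stated time of 48 h, tested at 20 uM (on this read-out higher numbers stand for more inhibition of growth at the one concentration tested and lower numbers for less inhibition of growth), compound 3 (`Cc1ccc(S(=O)(=O)Oc2cccc(/C=C(\C#N)C(=O)Nc3nnc(C)s3)c2)cc1`) gives 27% on the growth read-out. That number lies within the scatter of both close relatives: compound 1 (`N#C/C(=C\c1ccccc1OS(=O)(=O)c1ccc([N+](=O)[O-])cc1)C(=O)Nc1nnc(-c2cccs2)s1`) gives 33% in the same test, and compound 2 (`Cc1nnc(NC(=O)/C(C#N)=C/c2cccc(OS(C)(=O)=O)c2)s1`) gives 20% there.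

The unmeasured compound 4 (`Cc1ccc(S(=O)(=O)Oc2cccc(/C=C(\C#N)C(=O)Nc3nnc(-c4ccccc4)s3)c2)cc1`) changes one place in compound 3: phenyl in place of methyl on an aromatic carbon. This turns 5-methyl-1,3,4-thiadiazol-2-yl into 5-phenyl-1,3,4-thiadiazol-2-yl.

Among the compounds with values here, only one measured single change offers any guide, and it sits elsewhere in the molecule. With 4-methylphenyl in place of methyl on a sulfonyl sulfur, the result is a number 7 percentage points higher from compound 2 to compound 3 (within the scatter), a small step. Compound 1 differs from compound 3 in several places, so it gives no clean comparison.

A small upward step that stays within the scatter is therefore expected in this assay, an estimated a number 4 percentage points higher from compound 3 to compound 4 (within the scatter) in all. Compound 4 is estimated at 31%, with an expected range from 18% to 46% in this test.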

Compound 4, percent growth inhibition at one concentration: 52%
Estimate against measurement, compound 4: 21 percentage points below; measured number outside the range, above it.
By their numbers in this assay, from the lowest: compounds 2, 3 and 1 (each within the scatter of the next, the first and the last beyond it); then compound 4.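

In this assay, the change from 5-methyl-1,3,4-thiadiazol-2-yl to 5-phenyl-1,3,4-thiadiazol-2-yl gives a number 25 percentage points higher from compound 3 to compound 4 (beyond the scatter), the only step among these compounds that lies beyond the scatter. This aromatic carbon of the five-membered ring is therefore a place where swapping a group clearly moves the growth read-out, which the change on the sulfonyl sulfur did not show. The entering phenyl adds a six-membered aromatic ring of carbon only and no hydrogen-bond donors or acceptors, but nothing measured here explains the rise.

Going by these compounds, whether the rise needs an aromatic ring or only a larger group remains open; a butyl chain or a cyclohexyl ring on this carbon would separate the two. Also open, on these data alone, is whether a phenyl ring carrying an amine or a carboxylic acid would keep the rise, and whether the same step would appear with methyl on the sulfonyl sulfur.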